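The source may hold more compounds than are shown below. What is called first, only, known or untested is meant among the compounds shown, and "the series" means these compounds.

Compound 3 `O=[N+]([O-])c1ccc(S(=O)(=O)N2CC(n3cnc4c(Cl)nc(Cl)nc43)OCc3ccccc32)cc1` was tested in a functional assay on MCF7 cells (Homo sapiens) for cytotoxicity, read by sulforhodamine B assay, with a stated time of 3 days (a lower number here means a stronger inhibitor, a higher number a weaker inhibitor), where compound 3 gives 355 nM. Of the three numbers shown, this is the second highest, though compound 2 `O=[N+]([O-])c1ccccc1S(=O)(=O)N1CC(n2cnc3c(Cl)nc(Cl)nc32)OCc2ccccc21`, which gives 383 nM, sits so close that a 1.1-fold lower number from compound 2 to compound 3 (0.03 log units; within the scatter). Compound 1 `O=[N+]([O-])c1ccc(S(=O)(=O)N2C[C@@H](n3cnc4c(Cl)nc(Cl)nc43)OCc3ccccc32)cc1` gives 100 nM, and a 3.6-fold higher number from compound 1 to compound 3 (0.55 log units; beyond the scatter); this gap rests on (the fact that one of compounds 1 and 3 is drawn with a defined configuration and the other without, at the place where they differ).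

Compound 4 `O=c1cc[nH]c(=O)n1C1CN(S(=O)(=O)c2ccc([N+](=O)[O-])cc2)c2ccccc2CO1` has not yet been measured. It differs from compound 3 in a group of 8 heavy atoms (4 carbon, 2 nitrogen, 2 oxygen; one six-membered aromatic ring with 2 hetero atoms) in place of a group of 11 heavy atoms (5 carbon, 4 nitrogen, 2 chlorine; one five-membered aromatic ring with 2 hetero atoms, one six-membered aromatic ring with 2 hetero atoms), on a saturated ring carbon. Neither of the measured steps touches this change. One concerns only the drawn configuration at the stereocentre, the other exchanges 4-nitrophenyl for 2-nitrophenyl on the sulfonyl sulfur, and the larger of the two, a 3.6-fold higher number from compound 1 to compound 3 (0.55 log units; beyond the scatter), is modest. The exchange of the group on the saturated ring carbon is a much larger structural change than either, and nothing measured among these compounds shows what such an exchange does to the number. The expectation for compound 4 is therefore uncertain and leans toward a higher number, a 5.6-fold higher number from compound 3 to compound 4 (0.75 log units; beyond the scatter). Compound 4 is estimated at 2000 nM, with a range from 300 nM to 20000 nM.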

Compound 4, half-maximal inhibitory concentration: 44300 nM
Compound 4: middle estimate off by 22-fold (1.35 log units), on the low side; the measured number lies above the stated range.
By their numbers in this assay, from the lowest: compound 1; then compounds 3 and 2 (each within the scatter of the next); then compound 4.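

At the saturated ring carbon next to the ring oxygen, placing the group of 8 heavy atoms in place of the group of 11 heavy atoms gives a 120-fold higher number from compound 3 to compound 4 (2.10 log units; beyond the scatter) in this assay and marks this position as the one with the largest change in the number among these compounds. Neither the step in drawn configuration (a 3.6-fold higher number from compound 1 to compound 3 (0.55 log units; beyond the scatter)) nor the exchange of nitrophenyl groups on the sulfonyl sulfur (a 1.1-fold lower number from compound 2 to compound 3 (0.03 log units; within the scatter)) comes close to it. The measured numbers do not separate the parts of this exchange, such as the loss of the two chlorine atoms or of the five-membered aromatic ring, and nothing given here bears on the cause of the step.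

Left open is whether a smaller change at this position, such as an amine in place of one chlorine atom on the group of compound 3, would keep the number close to that of compound 3. From the compounds shown here alone, compound 4 is drawn without a configuration at the saturated ring carbon, and what a defined configuration would do to its number also stays open.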